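Cytotoxicity limits and a rearranged side chain

This account rests on a few compounds, and the source may have more. Where it says the series, first, only, none or still open, it means among the compounds named here.

Values measured in an ADME assay on HEK293 cells (Homo sapiens) for cytotoxicity, read by ATP content, with a stated time of 6 h (on this read-out higher numbers stand for lower toxicity in this test and lower numbers for higher toxicity in this test), follow, and each one is a limit.

Compound 1 `CCCCNc1nc(N)nc2ccn(Cc3ccccn3)c12` gives > 24000 nM as a limit
Compound 2 `COCCNc1nc(N)nc2ccn(Cc3ccccn3)c12` gives > 24000 nM as a limit
Compound 3 `COCCCNc1nc(N)nc2ccn(Cc3ccccn3)c12` gives > 24000 nM as a limit

Compound 3 stands at > 24000 nM and this is a limit, not a number. It has no position of its own within the series, which shows only the limit of > 24000 nM in this assay, at which 3 of the 3 values shown sit, and no measured value.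

In compound 4 `CCC(O)CNc1nc(N)nc2ccn(Cc3ccccn3)c12` the change is 1-hydroxypropyl in place of 2-methoxyethyl on a saturated chain carbon bound to a nitrogen on an aromatic ring and the two have the same atoms, joined differently. Cut one bond further out, the same difference reads 3-methoxypropyl to 2-hydroxybutyl.

Three measured side-chain changes bear on this one. They are a step that the two limits leave unreadable from compound 1 to compound 2 and a step that the two limits leave unreadable from compound 1 to compound 3 and a step that the two limits leave unreadable from compound 2 to compound 3 and none of them gives a size. No hydroxy-bearing chain has been measured yet, so this remains a weak guide. No step beyond the scatter, in either direction, is therefore expected in this assay and another limit is the likely report.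

The estimated move is a step that the limit leaves unreadable from compound 3 to compound 4 and it is expected to stay within the scatter.

For compound 4 the estimated value is 30000 nM with an expected range from 16000 nM to 60000 nM as its span.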

Compound 4, half-maximal cytotoxic concentration: > 24000 nM
Compound 4: no number, only a limit; the forecaster's own chance of this, stated with the estimate: 85%; the middle value does not contradict the limit.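

Compound 4 gives only a limit in this assay, as do compound 1, compound 2 and compound 3, so no step among these compounds can be read: the limit of > 24000 nM in this assay, at which 4 of the 4 values shown sit.

The compounds shown leave open whether these four side chains differ from one another at all on this read-out.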